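Propyl exchanged for cyclobutyl on the ring nitrogen

The compounds below may be only part of what the source reports. "The series", "measured", "known", "first", "only" and "open" are said of these compounds alone.

Among the measured compounds shown here, compound 2 `CCCNc1nc2ccsc2c(=O)n1CC` is one of two compounds measured so far in an assay on cells for inhibition of high affinity 3',5'-cyclic-AMP phosphodiesterase 7A (Homo sapiens), read by scintillation counting and cAMP accumulation, with a stated time of 30 min; on this read-out higher numbers stand for weaker inhibition and lower numbers for stronger inhibition; there compound 2 gives 1400 nM, the lower of the two numbers, though within the scatter of the other. For the measured compounds named here, its only neighbour is compound 1 `CCn1c(NC2CC2)nc2ccsc2c1=O`, which in this assay gives 2600 nM; the step of a 1.9-fold lower number from compound 1 to compound 2 (0.27 log units; within the scatter) lies within the scatter, so the two compounds cannot be ordered on this read-out. Compound 3 `CCn1c(NC2CCC2)nc2ccsc2c1=O` has not yet been measured. It differs from compound 2 in one place: cyclobutyl in place of propyl on a nitrogen on an aromatic ring. Going by the values given here, the only measured step that bears on this change is the one from compound 1 to compound 2, where a cyclopropyl gave way to a propyl without effect beyond the scatter. Returning to a ring, now a four-membered one, is therefore expected to move the number little, if at all. Compound 3 is accordingly expected to give 2000 nM in this assay, within a range of 700 nM to 6000 nM. That estimate corresponds to an expected step of a 1.4-fold higher number from compound 2 to compound 3 (0.15 log units; within the scatter), not beyond the scatter.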

Compound 3, half-maximal inhibitory concentration in the high affinity 3',5'-cyclic-AMP phosphodiesterase 7A assay: 300 nM
Estimate against measurement, compound 3: 6.7-fold (0.82 log units) above, outside the stated range (below it).
By their numbers in the high affinity 3',5'-cyclic-AMP phosphodiesterase 7A assay, from the lowest: compound 3; then compounds 2 and 1 (each within the scatter of the next).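

In the high affinity 3',5'-cyclic-AMP phosphodiesterase 7A assay the group on this nitrogen proves able to move the number well beyond the scatter, which the earlier pair could not show: the cyclobutyl gives a 4.7-fold lower number from compound 2 to compound 3 (0.67 log units; beyond the scatter) and an 8.7-fold lower number from compound 1 to compound 3 (0.94 log units; beyond the scatter). A non-aromatic ring as such does not account for this, as compound 1 carries the cyclopropyl and shows no such low number. In a physicochemical assay for solubility, in phosphate buffer, at pH 6.8 (a higher number here means a more soluble compound, a lower number a less soluble compound), compound 2 gives 69 ug/mL and compound 3 gives 6.3 ug/mL. The same exchange of propyl for cyclobutyl comes with a clear loss in the physicochemical assay: the measured solubility of compound 2, 69 ug/mL, and of compound 3, 6.3 ug/mL, an 11-fold lower number (1.04 log units; beyond the scatter)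

The compounds shown leave open whether a cyclopentyl group on this nitrogen would lower the number in the high affinity 3',5'-cyclic-AMP phosphodiesterase 7A assay further, or whether a branched chain such as isobutyl would match the cyclobutyl. They also leave open whether an oxetanyl group would keep that low number while giving a higher one in the physicochemical assay.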